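Replacing the diethylaminoethyl amide on compound 1

The source may hold more compounds than are shown below. What is called first, only, known or untested is meant among the compounds shown, and "the series" means these compounds.

Compound 1 `CCN(CC)CCNC(=O)c1ccc(C(CC)(CC)c2ccc(OCCC(O)(CC)CC)c(C)c2)n1CC` is the reference of this small set. In a functional assay on Caco-2 cells (Homo sapiens) for antiproliferative activity, read by MTT assay, with a stated time of 48 h (on this read-out higher numbers stand for weaker inhibition and lower numbers for stronger inhibition), compound 1 gives 1630 nM, the lowest of the numbers shown. Compound 3 `CCOC(=O)CN(C)C(=O)c1ccc(C(CC)(CC)c2ccc(OCCC(O)(CC)CC)c(C)c2)n1CC` gives 30300 nM in this assay. Compound 2 `CCn1c(C(=O)Nc2cccc(C(F)(F)F)c2)ccc1C(CC)(CC)c1ccc(OCCC(O)(CC)CC)c(C)c1` is reported only as a limit of this assay, > 50000 nM, and sits at the limit of > 50000 nM in this assay, at which 1 of the 3 values shown sits.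

The compound not yet measured is compound 4 `CCn1c(C(=O)N(C)CCO)ccc1C(CC)(CC)c1ccc(OCCC(O)(CC)CC)c(C)c1`. It differs from compound 1 by (2-hydroxyethyl)(methyl)amino in place of (2-(diethylamino)ethyl)amino on a carbonyl carbon.

For the measured compounds named here, two measured steps bear on this change, since both also remove the (2-(diethylamino)ethyl)amino group from the carbonyl carbon. The step of a 19-fold higher number from compound 1 to compound 3 (1.27 log units; beyond the scatter) replaced it with another tertiary amide and gave a large rise; the step of an at least 30-fold higher number from compound 1 to compound 2 (1.48 log units; beyond the scatter) gave an even larger rise, though that end is a limit. The step from compound 2 to compound 3, an at least 1.6-fold lower number from compound 2 to compound 3 (0.21 log units; that floor lies within the scatter), shows that the two replacements end up close to one another. Compound 4 keeps one hydrogen-bond donor, so its position is less certain, but the shared direction of both steps points to a clearly higher number.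

Compound 4 is therefore expected to give about 20000 nM in this assay, within a range of 5000 nM to 60000 nM, a step of a 12-fold higher number from compound 1 to compound 4 (1.09 log units; beyond the scatter) from compound 1.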

Compound 4, half-maximal inhibitory concentration: 74 nM
Compound 4: the middle estimate sits 270-fold (2.43 log units) above what was measured; the measured number lies below the stated range.
By their numbers in this assay, from the lowest: compound 4; then compound 1; then compound 3. At a limit, above all of these: compound 2.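

On this carbonyl carbon, the (2-(diethylamino)ethyl)amino group is not required for a low number in this assay: exchanging it for (2-hydroxyethyl)(methyl)amino gives a 22-fold lower number from compound 1 to compound 4 (1.34 log units; beyond the scatter), whereas the earlier replacements had moved the number only upwards. Compound 3 and compound 4 differ only by hydroxymethyl in place of ethoxycarbonyl on a saturated chain carbon bound to an amide-type nitrogen, and this single change gives a 410-fold lower number from compound 3 to compound 4 (2.61 log units; beyond the scatter), so among these two compounds the outcome follows the end of the chain and not the tertiary amide alone. Measured against the (3-(trifluoromethyl)phenyl)amino group, the replacement gives an at least 670-fold lower number from compound 2 to compound 4 (2.82 log units; beyond the scatter), and that size is only a floor, compound 2 being reported as a limit: the limit of > 50000 nM in this assay, at which 1 of the 4 values shown sits.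

The compounds shown do not separate the part played by the terminal hydroxyl from that of the methyl on the amide nitrogen, which a methoxy end, a primary amine, a carboxylic acid or a longer chain at this place could begin to resolve. Also open, from the compounds shown here alone, is whether the plain (2-hydroxyethyl)amino group would behave like compound 4.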